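The source may report more compounds than this note shows. Statements on the series, on what has been measured and on what is new or still open speak of the compounds shown alone.

Within the data shown here, in a functional assay on Ishikawa cells (Homo sapiens) for antiproliferative activity, read by CCK-8 assay, with a stated time of 48 h (on this read-out lower numbers stand for stronger inhibition and higher numbers for weaker inhibition), compound 3 `O=C(/C=C/CN1CC(Oc2ccc(Oc3c(-c4ccc(F)cc4)sc4cc(O)ccc34)cc2)C1)N1CCC1` gives 5450 nM, the lowest number so far, and compound 1 `CNC(=O)/C=C/CNCCOc1ccc(Oc2c(-c3ccc(F)cc3)sc3cc(O)ccc23)cc1` gives 15500 nM. For compound 2 `O=C(CCCNCCOc1ccc(Oc2c(-c3ccc(F)cc3)sc3cc(O)ccc23)cc1)N1CCC1` the result is only a limit, > 25000 nM.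

The next change leads to compound 4 `CN(C)C(=O)/C=C/CN1CC(Oc2ccc(Oc3c(-c4ccc(F)cc4)sc4cc(O)ccc34)cc2)C1`: dimethylamino in place of azetidin-1-yl on a carbonyl carbon. The ring on the carbonyl carbon is thus opened to dimethylamino, and the rest of compound 3 stays as it is.

Among the measured compounds shown here, only one measured step touches this amide: an at least 1.6-fold higher number from compound 1 to compound 2 (0.20 log units; that floor lies within the scatter). That step is a weak guide, since it replaces methylcarbamoyl with the azetidin-1-yl amide and also changes ethenyl to ethyl, and its size is bounded on one side only. For the measured compounds named here, no measured pair isolates the swap from azetidin-1-yl to dimethylamino.

In this assay no change beyond the scatter is therefore expected, with a slight drift to a higher number at most. The expected step is a 1.2-fold higher number from compound 3 to compound 4 (0.08 log units; within the scatter). For compound 4 the estimated value is 6500 nM, with an expected range of 3000 nM to 14000 nM.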

Compound 4, half-maximal inhibitory concentration: 11200 nM
Estimate against measurement, compound 4: 1.7-fold (0.24 log units) below; the measured number falls inside the stated range.
By their numbers in this assay, from the lowest: compound 3; then compounds 4 and 1 (each within the scatter of the next). At a limit, above all of these: compound 2.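

In this assay, among these compounds, dimethylamino in place of azetidin-1-yl on a carbonyl carbon gives a 2.1-fold higher number from compound 3 to compound 4 (0.31 log units; beyond the scatter), the first single swap on this amide with a size beyond the scatter and a firm number at both ends. Replacing the whole 2-((3-(methylcarbamoyl)prop-2-en-1-yl)amino)ethyl group on an oxygen on an aromatic ring gives a 1.4-fold lower number from compound 1 to compound 4 (0.14 log units; within the scatter), so that larger change leaves no readable difference. The remaining step rests on a limit rather than a number and gives only a floor: an at least 2.2-fold lower number from compound 2 to compound 4 (0.34 log units; beyond the scatter).

Still open, from the compounds shown here alone, is whether a larger ring on the carbonyl carbon, such as pyrrolidin-1-yl or piperidin-1-yl, would match azetidin-1-yl. Going by these compounds, the effect of the chain on the oxygen alone also stays open, since the steps from compound 1 and compound 2 change it together with the amide.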